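This account rests on a few compounds, and the source may have more. Where it says the series, first, only, none or still open, it means among the compounds named here.

Working notes on the urea series. In an ADME assay on HepG2 cells (Homo sapiens) for cytotoxicity, with a stated time of 72 h (a lower number here means that less compound is needed, a higher number that more compound is needed for the effect), compound 1 `Cc1cc(NC(=O)Nc2cccc(Cl)c2)c2ccccc2n1` gives 19000 nM, a number within the measured window. Compound 2 `Cc1cc(NC(=O)Nc2ccccc2C(N)=O)c2ccccc2n1` returns only a limit of the assay, > 25000 nM, not a number. Of the two values shown, compound 2 therefore sits at the upper edge, marked by the limit of > 25000 nM in this assay, at which 1 of the 2 values shown sits, while compound 1 stands below it with a measured value.

Compound 3 `COc1ccccc1NC(=O)Nc1cc(C)nc2ccccc12` has not yet been measured in this assay. It differs from compound 2 by methoxy in place of carbamoyl on an aromatic carbon. Going by the values given here, no step between two measured compounds that differ in one place is available, so the size of this change carries no measured precedent. Within this assay, a step from compound 2 to compound 3 of no more than the usual scatter, or at most a small move toward a lower number, is expected. Compound 3 is expected near 22000 nM, with a range from 8000 nM to 60000 nM. The implied step an at least 1.1-fold lower number from compound 2 to compound 3 (0.05 log units; that floor lies within the scatter) is an estimate, not a measurement.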

Compound 3, half-maximal effective concentration: > 25000 nM
Compound 3 ended at the assay's limit; the forecaster's own chance of this, stated with the estimate: 45%; middle value at least 1.1-fold (0.05 log units) away from the limit.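

Going by these compounds alone, compound 2 and compound 3 both return only a limit of the assay and not a number, so no step between them can be read. The compounds shown leave open whether methoxy in place of carbamoyl on an aromatic carbon changes the read-out in this assay at all.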